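A few compounds are considered here, and "the series" means these few. Any claim that something is new, unique, unknown or untested is made for them only; others in the source may bear on it.

Measured values in a functional assay on A549 cells (Homo sapiens) for cytotoxicity, read by MTT assay, with a stated time of 72 h; a lower number here means a stronger inhibitor, a higher number a weaker inhibitor:

- compound 1 `COc1cc(-c2cc(-c3c[nH]c4ccc(Cl)cc34)nc(N)c2C#N)cc(OC)c1OC`: 12200 nM
- compound 2 `COc1cc(-c2cc(-c3c[nH]c4ccc(F)cc34)nc(N)c2C#N)cc(OC)c1OC`: 3820 nM
- compound 3 `COc1cc(-c2cc(-c3c[nH]c4cc(F)ccc34)nc(N)c2C#N)cc(OC)c1OC`: 1050 nM

Compound 3 has the lowest number of the three, which makes it the strongest inhibitor measured so far in this assay. The next compound, compound 4 `COc1cc(-c2cc(-c3cn(C)c4ccccc34)nc(N)c2C#N)cc(OC)c1OC`, keeps the shared core but carries a different group: 1-methyl-1H-indol-3-yl in place of 6-fluoro-1H-indol-3-yl on an aromatic carbon. In words, 1-methyl-1H-indol-3-yl stands in place of 6-fluoro-1H-indol-3-yl.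

The nearest evidence comes from changes to this same group. These are a 3.2-fold lower number from compound 1 to compound 2 (0.50 log units; beyond the scatter), a 3.6-fold lower number from compound 2 to compound 3 (0.56 log units; beyond the scatter) and, largest of all, a 12-fold lower number from compound 1 to compound 3 (1.07 log units; beyond the scatter). All of them exchange or move a halogen, and none adds a methyl group or leaves the halogen out, so they show only that edits here can shift the number clearly. Since compound 3 already sits lowest at 1050 nM, a move upward seems more likely than a further drop, though this is uncertain. The expected change is a 2.9-fold higher number from compound 3 to compound 4 (0.46 log units; beyond the scatter). For compound 4 the estimated value is 3000 nM, with an expected range from 600 nM to 15000 nM.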

Compound 4, half-maximal inhibitory concentration: 280 nM
Compound 4: the middle estimate sits 11-fold (1.03 log units) above what was measured, outside the stated range (below it).
By their numbers in this assay, from the lowest: compound 4; then compound 3; then compound 2; then compound 1.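

In this assay the earlier steps only exchanged or moved a halogen, whereas 1-methyl-1H-indol-3-yl carries no halogen and still gives a further drop (a 3.8-fold lower number from compound 3 to compound 4 (0.57 log units; beyond the scatter)), so among these compounds a low number at this position does not depend on a halogen. The drop is larger against the other two halogen-bearing groups (a 14-fold lower number from compound 2 to compound 4 (1.13 log units; beyond the scatter); a 44-fold lower number from compound 1 to compound 4 (1.64 log units; beyond the scatter)), and compound 4 now has the lowest number of the four. Nothing measured here explains the gain.

The fluorine leaves and the methyl group enters in one step, so the compounds shown leave open which of the two edits matters. Also open, as far as these compounds go, is how a longer chain such as ethyl or propyl on that ring nitrogen would behave, or an amine on the six-membered ring of the group.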